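From Compound 2 to Compound 3: Fluorine Enters

A few compounds are considered here, and "the series" means these few. Any claim that something is new, unique, unknown or untested is made for them only; others in the source may bear on it.

In an ADME assay on BJ cells (Homo sapiens) for cytotoxicity, read by CellTiter-Glo and resazurin assay, with a stated time of 72 h (on this read-out lower numbers stand for an effect already at smaller amounts and higher numbers for an effect only at larger amounts of compound), compound 1 `CCOC(=O)CCCCCOc1cccc(CN(C(=O)c2ccc(-c3ccc4c(c3)OCCO4)cc2)C(C)C)c1` gives only a limit, > 24400 nM. Compound 2 `CCOC(=O)CCCCCOc1cccc(CN(C(=O)c2ccc(-c3cc(OC)cc(OC)c3)cc2)C(C)C)c1` likewise gives only a limit, > 26000 nM. Neither compound therefore has an exact number, and compound 2 can be placed only by its limit.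

Compound 3 `CCOC(=O)CCCCCOc1cccc(CN(C(=O)c2ccc(-c3cc(OC)ccc3F)cc2)C(C)C)c1` has not yet been measured. It differs from compound 2 in one group, and the rest of the structure stays the same: 2-fluoro-5-methoxyphenyl in place of 3,5-dimethoxyphenyl on an aromatic carbon.

Within the data shown here, the only measured step that bears on this change is a step that the two limits leave unreadable from compound 1 to compound 2. That step also exchanged one group for another on an aromatic carbon, but it provides no size to carry forward. The expectation therefore rests on compound 2, whose limit is > 26000 nM. On that basis, no step beyond the usual scatter is expected in this assay, and no direction can be favoured. The expected outcome is a number no higher from compound 2 to compound 3 (the limit leaves the size open). Compound 3 is estimated at 26000 nM, with an expected range from 14000 nM to 45000 nM, and it too may be reported only as a limit.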

Compound 3, half-maximal effective concentration: > 26000 nM
Compound 3: a limit, no number (the forecaster's own chance of this, stated with the estimate: 85%); the middle value sits exactly at the limit.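

In this assay compound 3 gives > 26000 nM as a limit and not a number. Among these compounds, compound 1, compound 2 and compound 3 all stand only as limits, and no step among them can be read. The compounds shown leave open at what concentration each would reach its half-maximal effect, and whether their differing aromatic groups change that concentration at all.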